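Butylamino to propyl on the nitrofuran hydrazone series

This account rests on a few compounds, and the source may have more. Where it says the series, first, only, none or still open, it means among the compounds named here.

In an ADME assay on LL24 cells (Homo sapiens) for inhibition, read by MTT assay, with a stated time of 24 h (a higher number here means a weaker inhibitor, a lower number a stronger inhibitor), compound 1 (`CCCCOc1ccc(C(=O)N/N=C/c2ccc([N+](=O)[O-])o2)cc1`) gives > 200000 nM, which is a limit and not a number. Compound 2 (`CCCOc1ccc(C(=O)N/N=C/c2ccc([N+](=O)[O-])o2)cc1`) gives > 200000 nM, also a limit. For the measured compounds named here, compound 3 (`CCCCNc1ccc(C(=O)N/N=C/c2ccc([N+](=O)[O-])o2)cc1`) gives 47000 nM, the only actual number among the three, and it is the strongest inhibitor so far in this assay. The other two values both sit at one limit: the limit of > 200000 nM in this assay, at which 2 of the 3 values shown sit.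

Compound 4 (`CCCc1ccc(C(=O)N/N=C/c2ccc([N+](=O)[O-])o2)cc1`) has propyl in place of butylamino on an aromatic carbon, para to a large group: propyl in place of butylamino on an aromatic carbon.

Going by the values given here, three measured steps bear on this change. The first, a step that the two limits leave unreadable from compound 1 to compound 2, cannot be sized, so it gives no guide to chain length. The other two are an at least 4.2-fold lower number from compound 1 to compound 3 (0.62 log units; beyond the scatter) and an at least 4.2-fold lower number from compound 2 to compound 3 (0.62 log units; beyond the scatter). Both reach butylamino from a chain without it, and both are beyond the scatter, although their true size is hidden by the limit. Among these three compounds, only the one with butylamino gives a number, and neither of the others goes against that pattern. Compound 4 also lacks butylamino, so a move back towards the limit is expected, with a higher number in this assay. The expected step is a 3.2-fold higher number from compound 3 to compound 4 (0.50 log units; beyond the scatter). A result reported only as a limit would be quite possible. Compound 4 is estimated at 150000 nM, with an expected range of 60000 nM to 400000 nM.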

Compound 4, half-maximal inhibitory concentration: 89000 nM
For compound 4 the middle estimate is 1.7-fold (0.23 log units) above the measured one, and the stated range covers the measured number.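

Compound 4 goes against the earlier reading, in which only the butylamino compound gave a number: in this assay the change shows a 1.9-fold higher number from compound 3 to compound 4 (0.28 log units; within the scatter), so the result gives no sign that butylamino is needed at this position, and propyl cannot be told apart from it here. Against the two compounds with an oxygen on the same aromatic carbon, propyl shows an at least 2.2-fold lower number from compound 2 to compound 4 (0.35 log units; beyond the scatter) and also an at least 2.2-fold lower number from compound 1 to compound 4 (0.35 log units; beyond the scatter), and the true size of both steps remains hidden. Among the four compounds, the pattern now divides by the atom on the aromatic carbon, with no compound against it, since only compound 1 and compound 2, the butoxy and propoxy compounds, remain as limits rather than numbers: the limit of > 200000 nM in this assay, at which 2 of the 4 values shown sit.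

Still open, as far as these compounds go, is how a butyl chain or a propylamino group would read at this position, either of which would separate the effect of chain length from that of the attached atom. Also open, from the compounds shown here alone, is whether a polar group such as a carboxylic acid or a dimethylamino group on the same carbon would keep a readable number.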